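Amide aryl variants on a shared core: step to compound 4

The compounds below may be only part of what the source reports. "The series", "measured", "known", "first", "only" and "open" are said of these compounds alone.

Measured in a functional assay on GTL 16 cells for antiproliferative activity against GTL 16 cell line (Homo sapiens), read by CCK-8 assay, with a stated time of 72 h; on this read-out lower numbers stand for stronger inhibition and higher numbers for weaker inhibition:
compound 1 `O=C(Nc1cccc(-c2oc3cc(-c4ccc(F)cc4)ccc3c(=O)c2O)c1)c1ccc(Br)cc1` gives 25400 nM
compound 2 `Cc1cccc(C(=O)Nc2cccc(-c3oc4cc(-c5ccc(F)cc5)ccc4c(=O)c3O)c2)c1` gives 10900 nM
compound 3 `COc1cc(OC)cc(C(=O)Nc2cccc(-c3oc4cc(-c5ccc(F)cc5)ccc4c(=O)c3O)c2)c1` gives 19600 nM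

Compound 3 stands second highest of the three numbers in this assay; its gaps to compound 1 and to compound 2 both lie within the scatter. Compound 4 `CCCc1ccc(C(=O)Nc2cccc(-c3oc4cc(-c5ccc(F)cc5)ccc4c(=O)c3O)c2)cc1` differs from it by 4-propylphenyl in place of 3,5-dimethoxyphenyl on a carbonyl carbon. The three amide aryl swaps already measured bear on this step: a 2.3-fold lower number from compound 1 to compound 2 (0.37 log units; beyond the scatter) was the only one beyond the scatter, while a 1.3-fold lower number from compound 1 to compound 3 (0.11 log units; within the scatter) and a 1.8-fold higher number from compound 2 to compound 3 (0.25 log units; within the scatter) stayed within it. Exchanging one amide aryl group for another has moved this assay little, so no step beyond the scatter is expected for compound 4, a 1.2-fold lower number from compound 3 to compound 4 (0.06 log units; within the scatter). Compound 4 is estimated at 17000 nM, with an expected range of 8000 nM to 40000 nM.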

Compound 4, half-maximal inhibitory concentration: 20400 nM
The estimate for compound 4 lay 1.2-fold (0.08 log units) below the measured number; low and high end bracket the measured number.
By their numbers in this assay, from the lowest: compounds 2, 3, 4 and 1 (each within the scatter of the next, the first and the last beyond it).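

In this assay, the all-carbon 4-propylphenyl in place of 3,5-dimethoxyphenyl on the carbonyl carbon gives a 1.0-fold higher number from compound 3 to compound 4 (0.02 log units; within the scatter), so losing both methoxy groups and adding a propyl chain leaves the read-out unresolved. The other comparisons, a 1.9-fold higher number from compound 2 to compound 4 (0.27 log units; within the scatter) and a 1.2-fold lower number from compound 1 to compound 4 (0.10 log units; within the scatter), also separate nothing, so compound 4 sits within the scatter of all three earlier amides. No measurement at hand accounts for this flat response.

Still open, as far as these compounds go, is whether an amine or a carboxylic acid on this aryl group would move the number beyond the scatter.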